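The source may hold more compounds than are shown below. What is called first, only, known or untested is meant among the compounds shown, and "the series" means these compounds.

Measured compounds in a functional assay on HepG2 cells (Homo sapiens) for inhibition, read by MTT assay, with a stated time of 72 h; a lower number here means a stronger inhibitor, a higher number a weaker inhibitor:
- compound 1 `COc1cccc(-n2cc(COc3cccc(NC(=O)Nc4ccc(Cl)c(C(F)(F)F)c4)c3)nn2)c1` gives 1310 nM
- compound 2 `CC(C)c1ccccc1-n1cc(COc2cccc(NC(=O)Nc3ccc(Cl)c(C(F)(F)F)c3)c2)nn1` gives 1900 nM
- compound 3 `O=C(Nc1cccc(OCc2cn(-c3cccc(Cl)c3)nn2)c1)Nc1ccc(Cl)c(C(F)(F)F)c1` gives 2020 nM

All three share one core and differ only in the aryl group on the aromatic nitrogen of the five-membered aromatic ring with 3 nitrogen. The spread among them is small: the step of a 1.5-fold higher number from compound 1 to compound 2 (0.16 log units; within the scatter) and the step of a 1.1-fold higher number from compound 2 to compound 3 (0.03 log units; within the scatter) both sit within the scatter, as does a 1.5-fold higher number from compound 1 to compound 3 (0.19 log units; within the scatter). Compound 3 therefore stands with compounds 1 and 2 in one cluster, with no gap to either that exceeds the scatter.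

Compound 4 `O=C(Nc1cccc(OCc2cn(-c3ccccc3C(F)(F)F)nn2)c1)Nc1ccc(Cl)c(C(F)(F)F)c1` continues the same exchange at the same place: 2-(trifluoromethyl)phenyl in place of 3-chlorophenyl on an aromatic nitrogen. Among the measured compounds shown here, the steps that bear on this are the three above, each of which left this assay unchanged beyond the scatter despite swaps among methoxy, isopropyl and chloro substituents on that phenyl. For the measured compounds named here, nothing among the measured compounds points to a direction for a trifluoromethyl-bearing phenyl, so no step beyond the scatter is expected: a 1.1-fold lower number from compound 3 to compound 4 (0.03 log units; within the scatter). Compound 4 is estimated at 1900 nM, with a range from 900 nM to 4200 nM.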

Compound 4, half-maximal inhibitory concentration: 2320 nM
Compound 4: middle estimate off by 1.2-fold (0.09 log units), on the low side; the range from low to high includes it.
By their numbers in this assay, from the lowest: compounds 1, 2, 3 and 4 (each within the scatter of the next).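

In this assay the flat response at the aromatic nitrogen now extends to a fourth aryl group and to a new substituent, with a 1.1-fold higher number from compound 3 to compound 4 (0.06 log units; within the scatter) for the exchange of 3-chlorophenyl for 2-(trifluoromethyl)phenyl and a 1.2-fold higher number from compound 2 to compound 4 (0.09 log units; within the scatter) for trifluoromethyl in place of isopropyl on an aromatic carbon. The largest gap in the set, a 1.8-fold higher number from compound 1 to compound 4 (0.25 log units; within the scatter) for 2-(trifluoromethyl)phenyl in place of 3-methoxyphenyl, also stays within the scatter, so all four compounds form one cluster in this assay. No measurement at hand accounts for this flat response.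

Still open, from the compounds shown here alone, is whether the cluster holds for a phenyl bearing an amine or a carboxylic acid, or for a longer alkyl chain in place of the aryl group. The four compounds also leave open whether any group at this position can move the number beyond the scatter.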